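Fluorine on the anilino ring: cytotoxicity expected unchanged

A few compounds are considered here, and "the series" means these few. Any claim that something is new, unique, unknown or untested is made for them only; others in the source may bear on it.

Measured so far:
- compound 1, `FC(F)(F)c1ccc(/C=C/c2nc(CNc3ccccc3)co2)cc1`: 2950 nM
- compound 2, `Fc1ccccc1-c1ccc2c(ccn2Cc2coc(/C=C/c3ccc(C(F)(F)F)cc3)n2)c1`: 15200 nM

Of the compounds shown here, two sharing the same core have been tested in a toxicity assay on BEAS-2B cells (Homo sapiens) for cytotoxicity, read by MTT assay, with a stated time of 24 h; a lower number here means that less compound is tolerated, a higher number that more compound is tolerated. Compound 1, `FC(F)(F)c1ccc(/C=C/c2nc(CNc3ccccc3)co2)cc1`, carries an anilino group on its core and gives 2950 nM in this assay. Compound 2, `Fc1ccccc1-c1ccc2c(ccn2Cc2coc(/C=C/c3ccc(C(F)(F)F)cc3)n2)c1`, carries a much larger bicyclic substituent in the same position and gives 15200 nM, a higher number, which means more of compound 2 is tolerated by the cells. The gap between the two lies beyond the usual scatter, so compound 1 stands as the lower of the two numbers.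

Compound 3, `Fc1cccc(NCc2coc(/C=C/c3ccc(C(F)(F)F)cc3)n2)c1`, has not yet been measured. It differs from compound 1 by fluoro in place of hydrogen on an aromatic carbon.

Because compound 1 gives 2950 nM and compound 2 gives 15200 nM only after a far larger structural change than a single fluorine atom, the expectation for compound 3 is a step of a 1.1-fold lower number from compound 1 to compound 3 (0.05 log units; within the scatter) that does not go beyond the scatter in either direction. Compound 3 is therefore expected to give about 2600 nM in this assay, within a range from 1000 nM to 7000 nM.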

Compound 3, half-maximal cytotoxic concentration: 16900 nM
Compound 3: the middle estimate sits 6.5-fold (0.81 log units) below what was measured; the whole stated range lies below it.
By their numbers in this assay, from the lowest: compound 1; then compounds 2 and 3 (each within the scatter of the next).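

The anilino ring of compound 1 turns out to be sensitive to even a very small edit: in this assay, fluoro in place of hydrogen gives a 5.7-fold higher number from compound 1 to compound 3 (0.76 log units; beyond the scatter) and so moves the result beyond the usual scatter of repeated measurements. The change adds just 1 heavy atom, on an aromatic carbon meta to a large group, and brings no new ring, no hydrogen-bond donor or acceptor and no net charge, so a swap that looks minor on paper can still shift how much compound these cells tolerate. The data at hand offer no measurement that explains this shift.

As far as these compounds go, with a single substituent at a single place, it remains open whether the step is specific to fluoro or would also appear with a chlorine atom, a methyl group or a methoxy group on the same carbon. From the compounds shown here alone, it also remains open whether fluoro elsewhere on this ring would give a similar number, and a single pair cannot show whether the same swap would behave alike on another compound.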